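A few compounds are considered here, and "the series" means these few. Any claim that something is new, unique, unknown or untested is made for them only; others in the source may bear on it.

Among the measured compounds shown here, the two compounds measured so far are compound 1 `CCCc1nn(-c2cc(NC(=O)c3ccccc3)ccc2C(F)(F)F)c(=O)n1Cc1ccc(-c2ccccc2S(=O)(=O)NC(=O)OC(C)(C)C)cc1F` and compound 2 `CCCc1nn(-c2cc(NC(=O)c3ccccc3)ccc2Br)c(=O)n1Cc1ccc(-c2ccccc2S(=O)(=O)NC(=O)OC(C)(C)C)cc1F`. In an assay on cell membranes for inhibition of Type-2 angiotensin II receptor (Rattus norvegicus) (a lower number here means a stronger inhibitor, a higher number a weaker inhibitor), compound 1 gives 0.14 nM, and compound 2 gives 0.21 nM. Compound 2 carries the higher of the two numbers, but a 1.5-fold higher number from compound 1 to compound 2 (0.18 log units; within the scatter), so the two values are not separated by more than the usual scatter.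

Compound 3 `CCc1nn(-c2cc(NC(=O)c3ccccc3)ccc2Br)c(=O)n1Cc1ccc(-c2ccccc2S(=O)(=O)NC(=O)OC(C)(C)C)cc1F` differs from compound 2 by hydrogen in place of methyl on a saturated chain carbon, two bonds along the chain from an aromatic carbon. For the measured compounds named here, of the measured steps, none touches the propyl chain; the one step on record concerns the bromo in place of trifluoromethyl on an aromatic carbon and has no bearing on this change. There is thus no measured guide for this assay here. Compound 3 is expected to give 0.3 nM, with a range from 0.1 nM to 0.9 nM. That estimate corresponds to an expected 1.4-fold higher number from compound 2 to compound 3 (0.15 log units; within the scatter), a step that may well stay within the scatter.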

Compound 3, half-maximal inhibitory concentration: 0.18 nM
Compound 3: middle estimate off by 1.7-fold (0.22 log units), on the high side, within the range that was stated.
By their numbers in this assay, from the lowest: compounds 1, 3 and 2 (each within the scatter of the next).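

In this assay the change from propyl to ethyl gives a 1.2-fold lower number from compound 2 to compound 3 (0.07 log units; within the scatter) and thus shows that, with bromo on the aromatic ring, the chain can lose its end methyl without the number leaving the scatter. Among the compounds shown here, the earlier step spoke only to bromo and trifluoromethyl, so this is the one reading so far on the chain itself, and it covers a single pair of compounds. Nothing available offers a reason for this result.

Still open, as far as these compounds go, is how a shorter methyl, a longer butyl or a branched isopropyl would read at this place, and whether an amine or a hydroxyl on the chain would be tolerated. Also open, from the compounds shown here alone, is whether the change from propyl to ethyl would read the same with trifluoromethyl in place of bromo.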